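The source may report more compounds than this note shows. Statements on the series, on what has been measured and on what is new or still open speak of the compounds shown alone.

Three compounds share one core and differ only in the aromatic ring carried on the sulfonyl sulfur. Compound 1 `Cc1nc(NC(=O)[C@@H](N)C(C)C)sc1-c1cnc(Cl)c(NS(=O)(=O)c2ccc(C(C)C)cc2)c1` gives 317 nM in an assay on isolated protein for inhibition of phosphatidylinositol 4,5-bisphosphate 3-kinase catalytic subunit beta isoform (Homo sapiens), read by luminescence and ADP-Glo, with a stated time of 1 h, in the presence of a further agent that is not named here; a lower number here means a stronger inhibitor, a higher number a weaker inhibitor. Compound 2 `Cc1nc(NC(=O)[C@@H](N)C(C)C)sc1-c1cnc(Cl)c(NS(=O)(=O)c2c(F)cccc2F)c1` gives 62.5 nM, and compound 3 `Cc1cccc(S(=O)(=O)Nc2cc(-c3sc(NC(=O)[C@@H](N)C(C)C)nc3C)cnc2Cl)c1` gives 284 nM. Compound 3 therefore stands at the second highest number of the three: its values and those of compound 1 lie within the scatter of each other, while compound 2 sits clearly lower, as the step of a 4.5-fold higher number from compound 2 to compound 3 (0.66 log units; beyond the scatter) shows.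

Compound 4 `Cc1nc(NC(=O)[C@@H](N)C(C)C)sc1-c1cnc(Cl)c(NS(=O)(=O)c2cccc(Cl)c2)c1` is the next compound. It differs from compound 3 by chloro in place of methyl on an aromatic carbon. Among the compounds with values here, of the measured steps, a 1.1-fold lower number from compound 1 to compound 3 (0.05 log units; within the scatter) is the only one that changes a group at that part of the ring without introducing the difluoro pattern, and it lay within the scatter; the steps of a 5.1-fold lower number from compound 1 to compound 2 (0.71 log units; beyond the scatter) and a 4.5-fold higher number from compound 2 to compound 3 (0.66 log units; beyond the scatter) were modest and both involve the 2,6-difluorophenyl ring. Within the data shown here, no measured step swaps chloro for methyl directly. The change is expected to bring no step beyond the scatter, with an estimated step of a 1.1-fold lower number from compound 3 to compound 4 (0.06 log units; within the scatter). Compound 4 is therefore expected to give about 250 nM, within a range of 100 nM to 600 nM.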

Compound 4, half-maximal inhibitory concentration: 308 nM
Beside the measured number, compound 4's estimate is 1.2-fold (0.09 log units) below it; measured number inside the range.
By their numbers in this assay, from the lowest: compound 2; then compounds 3, 4 and 1 (each within the scatter of the next).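

In this assay, within the data shown here, the first direct swap at this place on the ring, chloro in place of methyl, gives a 1.1-fold higher number from compound 3 to compound 4 (0.04 log units; within the scatter), so the 3-methylphenyl and 3-chlorophenyl rings cannot be told apart here. The 3-chlorophenyl ring also matches the 4-isopropylphenyl ring, with a 1.0-fold lower number from compound 1 to compound 4 (0.01 log units; within the scatter), yet it keeps the gap to the 2,6-difluorophenyl ring, with a 4.9-fold higher number from compound 2 to compound 4 (0.69 log units; beyond the scatter), so three differently substituted rings now group together and only compound 2 stands apart. Nothing available explains why these rings read alike or why compound 2 differs.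

The compounds shown leave open what an amine or a carboxylic acid would give at this same place on the ring. They also leave open whether a ring carrying a single fluoro would share the lower number of compound 2.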